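The source may hold more compounds than are shown below. What is called first, only, known or untested is meant among the compounds shown, and "the series" means these compounds.

Measured compounds:
- compound 1 `CC(C)=CCOc1ccc2c(c1)OC(c1ccc(C)cc1)CC2=O`: 4440 nM
- compound 2 `CC(C)=CCOc1ccc2c(c1)OC(c1ccc(O)cc1)CC2=O`: 6670 nM

Compound 1 and compound 2 share a core and differ only on the pendant aromatic ring. In a functional assay (on this read-out lower numbers stand for stronger inhibition and higher numbers for weaker inhibition), compound 1 gives 4440 nM, the lowest of the two numbers, and in this assay compound 2 gives 6670 nM; the step of a 1.5-fold higher number from compound 1 to compound 2 (0.18 log units; within the scatter) is within the scatter, so the two values cannot be ranked.

Compound 3 `CC(C)=CCOc1cc(O)c2c(c1)OC(c1ccc(C)cc1)CC2=O` is not yet measured. It differs from compound 1 by hydroxy in place of hydrogen on an aromatic carbon. Among the compounds with values here, the only measured step, from compound 1 to compound 2, exchanges groups on the other aromatic ring, not the core, so it bears only loosely on this change; it shows that placing a hydroxy group on an aromatic carbon, in that case instead of methyl, moved the number by no more than the scatter. Within the data shown here, no step on the core itself is available. On that basis the expectation for compound 3 is a step of a 1.0-fold higher number from compound 1 to compound 3 (0.01 log units; within the scatter), that is, no change beyond the scatter. Compound 3 is therefore estimated at 4500 nM, within a range of 1800 nM to 11000 nM.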

Compound 3, half-maximal inhibitory concentration: 4360 nM
The estimate for compound 3 lay 1.0-fold (0.01 log units) above the measured number, within the range that was stated.
By their numbers in this assay, from the lowest: compounds 3, 1 and 2 (each within the scatter of the next).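

In this assay, within the data shown here, putting hydroxy in place of hydrogen on the core gives a 1.0-fold lower number from compound 1 to compound 3 (0.01 log units; within the scatter), so this aromatic carbon, ortho to a fused ring and meta to the (3-methylbut-2-en-1-yl)oxy group, now has a direct reading where the earlier compounds offered only a change on the pendant ring. Compound 1 and compound 3 cannot be ranked, which means that this added hydroxy, with its hydrogen-bond donor and acceptor, leaves no mark on the number that stands out from ordinary repeat variation. Nothing available explains why the two numbers cannot be told apart.

The compounds shown leave open whether a methoxy group or an amine on this same aromatic carbon would also stay within the scatter of compound 1 or would move the number beyond it. They also leave open whether a hydroxy on the core and a hydroxy on the pendant ring would stay within the scatter when present together, and whether a longer chain in place of the (3-methylbut-2-en-1-yl)oxy group would change the number.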